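A ring swap on the amide-type nitrogen

The source may hold more compounds than are shown below. What is called first, only, known or untested is meant among the compounds shown, and "the series" means these compounds.

Values so far in a physicochemical assay for solubility, read by nephelometry, measured as kinetic solubility, at pH 2 (on this read-out lower numbers stand for lower solubility and higher numbers for higher solubility), are these.
Compound 1 `N#Cc1ccc(NC(=O)Nc2ccnc(C(F)(F)F)c2)cc1` gives 1.6 ug/mL in this series
Compound 2 `O=C(Nc1ccc(F)c(C(F)(F)F)c1)Nc1cnccn1` gives 1.6 ug/mL in this series
Compound 3 `O=C(Nc1ccc(F)c(C(F)(F)F)c1)Nc1ccccn1` gives 1.6 ug/mL in this series

In this assay compound 3 stands level with compound 1 and compound 2 at the digits reported, so none of the three can be ranked against the others. The next compound to be read is compound 4 `Cc1cc(NC(=O)Nc2ccc(F)c(C(F)(F)F)c2)on1`, which has no value yet. It departs from compound 3 as follows: 3-methyl-1,2-oxazol-5-yl in place of pyridin-2-yl on an amide-type nitrogen and so, in words, 3-methyl-1,2-oxazol-5-yl in place of pyridin-2-yl on an amide-type nitrogen.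

Going by the values given here, only one measured step touches that place. With pyridin-2-yl in place of pyrazin-2-yl, the reading showed no change at the digits printed from compound 2 to compound 3 (within the scatter) and so stayed within the scatter. Among the compounds with values here, that step involves six-membered rings only, and no measured compound carries a five-membered aromatic ring there, so it is a thin guide. Within the data shown here, compound 1 differs from compound 3 in more than one place and offers no step to draw on.

On this evidence the expected change is small, with no clear direction. The estimated move is a 1.1-fold higher number from compound 3 to compound 4 (0.05 log units; within the scatter) and is not expected to exceed the scatter. The estimate for compound 4 is 1.8 ug/mL with an expected range from 1.1 ug/mL to 5 ug/mL in this assay when it is read.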

Compound 4, solubility: 12.5 ug/mL
For compound 4 the middle estimate is 6.9-fold (0.84 log units) below the measured one; the whole stated range lies below it.
By their numbers in this assay, from the lowest: compounds 1, 2 and 3 (each within the scatter of the next); then compound 4.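

In this assay, 3-methyl-1,2-oxazol-5-yl on the amide-type nitrogen gives a 7.8-fold higher number from compound 3 to compound 4 (0.89 log units; beyond the scatter) when it replaces pyridin-2-yl and a 7.8-fold higher number from compound 2 to compound 4 (0.89 log units; beyond the scatter) when it replaces pyrazin-2-yl, and both steps lie beyond the scatter. Going by these compounds alone, the earlier compounds offered only an exchange of one six-membered aromatic ring for another at this place, no change at the digits printed from compound 2 to compound 3 (within the scatter), so compound 4 is the first sign that the read-out can move with the group on this nitrogen, at least with a five-membered aromatic ring carrying 2 hetero atoms. Nothing at hand shows what lies behind this rise.

The compounds shown leave open whether the move belongs to the five-membered ring, to its hetero atoms or to its methyl group, as all three arrive together in compound 4. They also leave open what the same ring would do with a carboxylic acid or an amine in place of the methyl, and whether the step would carry over to the core of compound 1.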